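Methoxy for methyl on the aryl thiosemicarbazone of compound 1

The source may report more compounds than this note shows. Statements on the series, on what has been measured and on what is new or still open speak of the compounds shown alone.

Three thiosemicarbazones have been measured in a functional assay on SGC-7901 cells (Homo sapiens) for antiproliferative activity, read by sulforhodamine B assay, with a stated time of 72 h; on this read-out higher numbers stand for weaker inhibition and lower numbers for stronger inhibition. Compound 1 `Cc1ccccc1NC(=S)N/N=C/c1ccc2ccccc2n1` returns no number in this assay: its result, > 100000 nM, is a limit of the assay. Evidence for that reading is the limit of > 100000 nM in this assay, at which 1 of the 3 values shown sits. The two dimethyl analogues on different cores read differently: compound 2 `CN(C)C(=S)N/N=C/c1cnc2ccccc2n1` gives 170 nM in this assay, and compound 3 `CN(C)C(=S)N/N=C/c1ccc2cccnc2n1` gives 630 nM. Going by the values given here, no step between these two is recorded, so only their two values stand side by side.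

Compound 4 `COc1ccccc1NC(=S)N/N=C/c1ccc2ccccc2n1` has not been measured in this assay. It differs from compound 1 in one place: methoxy in place of methyl on an aromatic carbon. The change sits on an aromatic carbon of a six-membered aromatic ring of carbon only, ortho to a large group.

Compound 1 sits at the limit of the assay, and the change is a small one on the outer aryl group, far from the hydrazone. Among the compounds with values here, no measured step informs the size of this change; the working expectation is no move beyond the scatter, with compound 4 also expected at or near the limit, so the step from compound 1 to compound 4 is estimated as a step that the limit leaves unreadable from compound 1 to compound 4. Compound 4 is estimated at 150000 nM, in the range from 30000 nM to 1000000 nM.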

Compound 4, half-maximal inhibitory concentration: > 100000 nM
Compound 4 was reported as a limit (the forecaster's own chance of this, stated with the estimate: 75%); the middle value is on the limit's open side.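

Compound 1 and compound 4 both return only a limit in this assay, so the change from 2-methylphenyl to 2-methoxyphenyl gives no readable step: the limit of > 100000 nM in this assay, at which 2 of the 4 values shown sit.

The compounds shown leave open whether any change on the outer aryl group of compound 1 would bring a measurable value in this assay.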